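Working notes: from ethoxymethyl to hydroxymethyl

The source may hold more compounds than are shown below. What is called first, only, known or untested is meant among the compounds shown, and "the series" means these compounds.

Values in an in vivo ADME assay on the whole organism (strain Sprague-Dawley) for pharmacokinetics, with Rattus norvegicus as the target; a lower number here means that a smaller share of the oral dose reaches the circulation, a higher number that a larger share of the oral dose reaches the circulation:
- Compound 1 `CCOC[C@H]1C[C@@](CC(C)C)(C(=O)O)N(C(=O)c2ccc(C(C)(C)C)c(OC)c2)[C@H]1c1nccs1`: 120%
- Compound 2 `CC(C)C[C@@]1(C(=O)O)C[C@H](C(N)=O)[C@H](c2nccs2)N1C(=O)c1ccc(C(C)(C)C)c(Cl)c1`: 5%
- Compound 3 `CC(C)C[C@@]1(C(=O)O)C[C@H](C(N)=O)[C@H](c2nccs2)N1C(=O)c1ccc(C(C)(C)C)cc1`: 2%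

Compound 1 stands highest of the three, with the gaps to compound 2 and compound 3 beyond the scatter. Compound 4 `COc1cc(C(=O)N2[C@@H](c3nccs3)[C@@H](CO)C[C@@]2(CC(C)C)C(=O)O)ccc1C(C)(C)C` keeps the core of compound 1 and changes one group: hydrogen in place of ethyl on an oxygen on a saturated carbon, ethoxymethyl to hydroxymethyl. For the measured compounds named here, no measured step covers this change. The only one, a number 3 percentage points lower from compound 2 to compound 3 (within the scatter), is hydrogen in place of chloro on an aromatic carbon, and it lies within the scatter, so it gives no direct guide. With compound 2 at 5% and compound 3 at 2%, values far under that of compound 1 do occur here, though both differ from it in more than one place. A drop of uncertain size is therefore expected in this assay. For compound 4 the expected change is a number 80 percentage points lower from compound 1 to compound 4 (beyond the scatter). Compound 4 is estimated at 40%, with an expected range from 10% to 90%.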

Compound 4, oral bioavailability: 12%
For compound 4 the middle estimate is 28 percentage points above the measured one, within the range that was stated.
By their numbers in this assay, from the lowest: compounds 3, 2 and 4 (each within the scatter of the next); then compound 1.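

In this assay, the group on this oxygen matters: hydrogen in place of ethyl gives a number 108 percentage points lower from compound 1 to compound 4 (beyond the scatter) and counts as a large step. The only earlier single-place step, on an aromatic carbon, stayed within the scatter, so this is the first position shown to move the read-out beyond it. Nothing available explains the size of this step.

Still open, from the compounds shown here alone, is whether a methyl or a longer chain on this oxygen would keep the higher value of compound 1. An amine or a carboxylic acid in place of the hydroxy group also remains untested among the compounds shown.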